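This account rests on a few compounds, and the source may have more. Where it says the series, first, only, none or still open, it means among the compounds named here.

Measured so far:
- compound 1, `O=C(Cc1cccnc1)c1cc2cc(-c3ccccc3)ccc2[nH]1`, 96000 nM
- compound 2, `O=C(Cc1cccnc1)c1cc2ccccc2[nH]1`, 65000 nM
- compound 3, `Cn1c(C(=O)Cc2cccnc2)cc2ccccc21`, 34000 nM

All three compounds were tested in an assay on isolated protein for inhibition of Indoleamine 2,3-dioxygenase 1 (Homo sapiens), read by spectrophotometry; on this read-out lower numbers stand for stronger inhibition and higher numbers for weaker inhibition. Compound 2 stands in the middle of the three numbers: the step of a 1.5-fold lower number from compound 1 to compound 2 (0.17 log units; within the scatter) and the step of a 1.9-fold lower number from compound 2 to compound 3 (0.28 log units; within the scatter) are both within the scatter, so the three compounds cannot be told apart on these data.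

Compound 4, `CC(C(=O)c1cc2ccccc2[nH]1)c1cccnc1`, has not yet been measured. It differs from compound 2 by methyl in place of hydrogen on a saturated chain carbon bound to an aromatic carbon and a carbonyl carbon. Neither of the measured steps touches this chain carbon: the step from compound 1 to compound 2 changes a group on an aromatic carbon and the step from compound 2 to compound 3 changes a group on an aromatic nitrogen, and both stayed within the scatter. There is therefore no measured guide for this change, and the expectation for compound 4 is a step of no change at the digits printed from compound 2 to compound 4 (within the scatter), that is no change beyond the scatter. Compound 4 is estimated at 65000 nM, with a likely range from 20000 nM to 200000 nM.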

Compound 4, half-maximal inhibitory concentration: 141000 nM
Compound 4: the middle estimate sits 2.2-fold (0.34 log units) below what was measured; measured number inside the range.
By their numbers in this assay, from the lowest: compounds 3, 2, 1 and 4 (each within the scatter of the next, the first and the last beyond it).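

Among these compounds, this chain carbon is the first place in the set where a single change moves the number beyond the scatter: in this assay, methyl in place of hydrogen gives weaker inhibition (a 2.2-fold higher number from compound 2 to compound 4 (0.34 log units; beyond the scatter)). The step is modest, but it shows that this position does respond to substitution, even with a group of 1 heavy atom, and that here the response runs towards weaker inhibition. Nothing available explains this result.

On these data alone, whether an ethyl group or a longer chain on this carbon would weaken inhibition further, or a hydroxyl group or an amine would act differently, remains open. Also open, as far as these compounds go, is how this chain methyl would combine with the methyl on the aromatic nitrogen of compound 3.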